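A Second Trifluoromethyl Group on Two Related Cores

This account rests on a few compounds, and the source may have more. Where it says the series, first, only, none or still open, it means among the compounds named here.

The compounds here were tested in a functional assay on A549 cells (Homo sapiens) for inhibition, read by MTT assay, with a stated time of 72 h; on this read-out lower numbers stand for stronger inhibition and higher numbers for weaker inhibition. Compound 1, with the structure `CNc1nc(C)c(C(=O)N/N=C/c2cccc(C(F)(F)F)c2)s1`, carries one trifluoromethyl group on its outer aromatic ring. In this assay compound 1 gives > 100 ug/mL, which is a limit of the assay rather than a number. Compound 2, `CNc1nc(C)c(C(=O)N/N=C/c2cc(C(F)(F)F)cc(C(F)(F)F)c2)s1`, differs from compound 1 only by trifluoromethyl in place of hydrogen on an aromatic carbon. In this assay compound 2 also gives > 100 ug/mL, again a limit and not a number. The step that the two limits leave unreadable from compound 1 to compound 2 therefore cannot be read, because the limit of > 100 ug/mL in this assay, at which 2 of the 3 values shown sit, hides whatever difference there may be.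

Compound 3, `CN(C(=O)NC(=O)c1ccc(C(F)(F)F)cc1)c1nc(C(F)(F)F)c(C(=O)N/N=C/c2cccc(C(F)(F)F)c2)s1`, is built on a different core; the difference between the two cores is not broken down here. In this assay compound 3 gives 6.66 ug/mL, the only value among these compounds that is a number rather than a limit.

Compound 4, `CN(C(=O)NC(=O)c1ccc(C(F)(F)F)cc1)c1nc(C(F)(F)F)c(C(=O)N/N=C/c2cc(C(F)(F)F)cc(C(F)(F)F)c2)s1`, is not yet measured. It stands to compound 3 as compound 2 stands to compound 1: the change is trifluoromethyl in place of hydrogen on an aromatic carbon, the same change in the same place. Since the earlier step between compound 1 and compound 2 is unreadable, there is no measured guide to its size, and the change adds no hydrogen-bond donors or acceptors. The step is expected to be about a 1.2-fold higher number from compound 3 to compound 4 (0.08 log units; within the scatter). Compound 4 is therefore estimated at 8 ug/mL, with a likely range from 3 ug/mL to 25 ug/mL.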

Compound 4, half-maximal inhibitory concentration: 5.9 ug/mL
The estimate for compound 4 lay 1.4-fold (0.13 log units) above the measured number; the range from low to high includes it.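

On the core of compound 3, the added trifluoromethyl group gives a 1.1-fold lower number from compound 3 to compound 4 (0.05 log units; within the scatter) in this assay, so the two compounds cannot be told apart on this read-out. The same change on the core of compound 1 cannot be read, because neither compound on that core gives a number, only a limit: the limit of > 100 ug/mL in this assay, at which 2 of the 4 values shown sit. This leaves a single readable step, on one core only, so the change shows no visible effect there, but nothing shows whether that result carries over from one core to the other, since a comparison would need a readable step on each.

The compounds shown vary only the trifluoromethyl groups on the outer aromatic ring, so it remains open whether an amine, a carboxylic acid or a longer chain in that place would shift the result on the core of compound 3 by more than the usual scatter. Also open, going by these compounds, is which part of the difference between the two cores goes with compound 3 and compound 4 giving numbers, while compound 1 and compound 2 give only limits.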